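Chloro-for-hydrogen exchange on a purine-type core

The source may hold more compounds than are shown below. What is called first, only, known or untested is meant among the compounds shown, and "the series" means these compounds.

The measured compounds and their values:
compound 1, `ClCc1cccc(Cn2cnc3c(Cl)ncnc32)c1`, 1820 nM;
compound 2, `ClCc1ccc(Cn2cnc3nc(Cl)nc(Cl)c32)cc1`, 1650 nM;
compound 3, `ClCc1cccc(Cn2cnc3c(Cl)nc(Cl)nc32)c1`, 1860 nM.

All three were tested in a functional assay on UACC-62 cells (Homo sapiens) for cytotoxicity, read by sulforhodamine B assay, with a stated time of 48 h; on this read-out higher numbers stand for weaker inhibition of growth and lower numbers for stronger inhibition of growth. Compound 1 gives 1820 nM, compound 2 gives 1650 nM and compound 3 gives 1860 nM. The three numbers sit close to one another, and none of the gaps between them is larger than the usual scatter of such measurements, so no ordering among them can be read from this assay.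

Compound 1 and compound 3 differ in one place only, (hydrogen in place of chloro on an aromatic carbon). The step that this change produced is a 1.0-fold lower number from compound 3 to compound 1 (0.01 log units; within the scatter). The cores of compound 2 and compound 3 are built from the same atoms joined differently; the difference between the two cores is not broken down here.

Compound 4, `ClCc1ccc(Cn2cnc3ncnc(Cl)c32)cc1`, has not yet been measured in this assay. Among the compounds with values here, it is related to compound 2 by hydrogen in place of chloro on an aromatic carbon, and this is the same change as the one from compound 3 to compound 1, since the place described around it is the same in both pairs. Because the measured step was a 1.0-fold lower number from compound 3 to compound 1 (0.01 log units; within the scatter), the corresponding step from compound 2 to compound 4 is expected to be of similar size, namely a 1.0-fold higher number from compound 2 to compound 4 (0.01 log units; within the scatter). On that basis compound 4 is estimated to give 1700 nM in this assay, with a likely range from 800 nM to 3600 nM.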

Compound 4, concentration for 50% growth inhibition: 2510 nM
Beside the measured number, compound 4's estimate is 1.5-fold (0.17 log units) below it, and the stated range covers the measured number.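

In this assay, the exchange of chloro for hydrogen on the second core gives a 1.5-fold higher number from compound 2 to compound 4 (0.18 log units; within the scatter). Set beside the earlier step on the other core, the two results do not differ by more than such pairs of steps normally would: the same change on two cores in this assay, a 1.0-fold lower number (0.01 log units; within the scatter) from compound 3 to compound 1 and a 1.5-fold higher number (0.18 log units; within the scatter) from compound 2 to compound 4, 1.6-fold (0.19 log units) apart, within the scatter of two such steps. This shows that, on these two cores, the exchange leaves no step beyond the scatter and no measurable difference between the cores, but it does not show that the cores respond alike in general: two pairs cannot establish a rule for the series, and steps this small would not reveal a modest difference between the cores.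

The compounds shown leave open how an amine or a methoxy group would read at the place between two ring nitrogen atoms, where only chloro and hydrogen appear here. All four compounds also carry a chloromethyl group, so what a methyl or hydroxymethyl group in its place would do to growth inhibition remains an open question.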